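Cyclohexyl in place of 4-methylphenyl on the ring nitrogen

The compounds below may be only part of what the source reports. "The series", "measured", "known", "first", "only" and "open" are said of these compounds alone.

Measured compounds:
compound 1 `COC(=O)c1nnn([C@@H]2C(=O)N(c3ccc(C)cc3)[C@@H]2/C=C/c2ccccc2)c1C(=O)OC` — "not determined" (no result reported)
compound 2 `O=C1[C@@H](n2cc(-c3ccccc3)nn2)[C@@H](/C=C/c2ccccc2)N1c1ccccc1` — 10%
compound 3 `Cc1ccc(N2C(=O)[C@@H](n3cc(-c4ccccc4)nn3)[C@H]2/C=C/c2ccccc2)cc1` — 14.7%

Among the measured compounds shown here, in a functional assay on KB cells (Homo sapiens) for inhibition, tested at 10 uM (a higher number here means more inhibition of growth at the concentration tested, a lower number less inhibition of growth), compound 2 gives 10% and compound 3 gives 14.7%; the only measured step, a number 4.7 percentage points higher from compound 2 to compound 3 (within the scatter), is small. Compound 1 has no number in this assay, so it stands nowhere on this scale; its two neighbours show only low growth inhibition. Compound 4 `COC(=O)c1nnn([C@@H]2C(=O)N(C3CCCCC3)[C@@H]2/C=C/c2ccccc2)c1C(=O)OC` differs from compound 1 by cyclohexyl in place of 4-methylphenyl on an amide-type nitrogen in a ring. For the measured compounds named here, no measured step touches this change, and the methyl-for-hydrogen step bears on it only loosely. Without a direct step, no shift beyond the scatter can be claimed in either direction; both measured values sit low. Compound 4 is therefore expected to give about 12%, in a range from 0% to 30%.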

Compound 4, percent growth inhibition at one concentration: -7.7%
Beside the measured number, compound 4's estimate is 19.7 percentage points above it; measured number outside the range, below it.
By their numbers in this assay, from the lowest: compound 4; then compounds 2 and 3 (each within the scatter of the next).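

In this assay, among the compounds shown here, compound 1 is recorded as "not determined" (no result reported) and compound 4 gives -7.7% so no step from compound 1 to compound 4 can be read. As far as these compounds go, what cyclohexyl in place of 4-methylphenyl does to growth inhibition stays open, and no evidence bears on the value of compound 4.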